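Chloro Added to a Fluoro-Bearing Ring: Expected Growth Inhibition

The source may hold more compounds than are shown below. What is called first, only, known or untested is meant among the compounds shown, and "the series" means these compounds.

Measured compounds:
compound 1 `O=c1c(C2N=C(c3ccccc3)SS2)coc2cc(Cl)c(Cl)cc12`: 70%
compound 2 `O=c1c(C2N=C(c3ccccc3)SS2)coc2ccc(F)cc12`: 32%
compound 3 `O=c1c(C2N=C(c3ccccc3)SS2)coc2ccccc12`: 23%

Of the compounds shown here, three built on one shared core have been tested in a functional assay on PC-3 cells (Homo sapiens) for inhibition, read by sulforhodamine B assay, with a stated time of 48 h, tested at 100 uM; on this read-out lower numbers stand for less inhibition of growth and higher numbers for more inhibition of growth at the one concentration tested. Among them compound 2 stands second highest. Its nearest neighbour is compound 3, and the change a number 9 percentage points lower from compound 2 to compound 3 (within the scatter) from hydrogen in place of fluoro on an aromatic carbon is within the scatter, so the two cannot be ordered. Compound 1, carrying two chloro groups on the same ring, lies beyond the scatter above compound 2.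

Compound 4 `O=c1c(C2N=C(c3ccccc3)SS2)coc2cc(Cl)c(F)cc12` differs from compound 2 by chloro in place of hydrogen on an aromatic carbon, ortho to a fluoro group. Within the data shown here, no measured step swaps a single hydrogen for chloro, so only indirect evidence exists. Among the measured compounds shown here, the one step on this ring, from compound 2 to compound 3, is within the scatter and says little. Compound 1 and compound 3 differ in two places; compound 1 gives 70% while compound 3 gives 23%, which suggests chloro groups on this ring go with more inhibition.

Compound 4 is therefore expected to rise in this assay by roughly a number 18 percentage points higher from compound 2 to compound 4 (beyond the scatter). The estimate for compound 4 is 50%, with a range from 30% to 70%.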

Compound 4, percent growth inhibition at one concentration: 76%
Beside the measured number, compound 4's estimate is 26 percentage points below it, and the stated range ends below it.
By their numbers in this assay, from the lowest: compounds 3 and 2 (each within the scatter of the next); then compounds 1 and 4 (each within the scatter of the next).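

In this assay, among these compounds, chloro in place of hydrogen on an aromatic carbon, ortho to a fluoro group, gives a number 44 percentage points higher from compound 2 to compound 4 (beyond the scatter) and is the first single-place chloro step, unlike the earlier step on this ring, which stayed within the scatter. Fluoro in place of chloro on this ring gives a number 6 percentage points higher from compound 1 to compound 4 (within the scatter) and so cannot order these two compounds: once this chloro is present, a fluoro group and a second chloro group read alike within the scatter. Nothing shown here bears on why adding this one atom goes with so large a step.

Open, going by these compounds, is whether this chloro would give a step of similar size on the ring of compound 3, where no fluoro group is present, which would show whether the large step depends on the fluoro group. Also open, on these data alone, is how a methyl, a methoxy, an amine or a carboxylic acid would read in this same place, and whether the large step would hold at other concentrations.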